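Hydroxy for nitro on the hydrazone aryl ring

A few compounds are considered here, and "the series" means these few. Any claim that something is new, unique, unknown or untested is made for them only; others in the source may bear on it.

Compound 2 `O=C(CSc1nnc(-c2ccncc2)o1)N/N=C/c1ccc([N+](=O)[O-])cc1` is the weaker of the two measured compounds in a functional assay on MCF7 cells (Homo sapiens) for cytotoxicity, read by MTT assay, with a stated time of 48 h (on this read-out lower numbers stand for stronger inhibition and higher numbers for weaker inhibition), where compound 2 gives 31800 nM; its nearest neighbour, compound 1 `O=C(CSc1nnc(-c2ccncc2)o1)N/N=C/c1ccc(Cl)cc1`, gives 15300 nM. Among the measured compounds shown here, the only measured step, a 2.1-fold higher number from compound 1 to compound 2 (0.32 log units; beyond the scatter), shows that a nitro in place of chloro on that aromatic carbon raised the number modestly. Compound 3 `O=C(CSc1nnc(-c2ccncc2)o1)N/N=C/c1ccc(O)cc1` takes the step from compound 2 in a different direction: hydroxy in place of nitro on an aromatic carbon. For the measured compounds named here, no measured step exchanges the nitro for a hydroxy, so the single step from compound 1 to compound 2 is the only guide, and it was small. A change of similar size in either direction, or none beyond the scatter, is therefore expected for compound 3 in this assay; the estimate is a 1.4-fold lower number from compound 2 to compound 3 (0.16 log units; within the scatter). Compound 3 is estimated at 22000 nM, with a range from 8000 nM to 60000 nM.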

Compound 3, half-maximal inhibitory concentration: 11700 nM
Compound 3: the middle estimate sits 1.9-fold (0.27 log units) above what was measured, and the stated range covers the measured number.
By their numbers in this assay, from the lowest: compounds 3 and 1 (each within the scatter of the next); then compound 2.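

In this assay, hydroxy in place of nitro gives a 2.7-fold lower number from compound 2 to compound 3 (0.43 log units; beyond the scatter), so compound 2 now stands apart from both of the other compounds at this position on the aromatic ring. Hydroxy in place of chloro gives a 1.3-fold lower number from compound 1 to compound 3 (0.12 log units; within the scatter), so these two groups cannot be told apart here, although they differ as substituents, and among the three compounds shown only the nitro separates from the rest. No measurement at hand explains why the nitro stands apart.

The compounds shown leave open whether an amine, a methoxy group or a carboxylic acid at this position would fall with chloro and hydroxy or with the nitro. They also leave open whether this small spread holds once the rest of the shared core is changed.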